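From 3-aminophenyl to 4-hydroxyphenyl on compound 3

This account rests on a few compounds, and the source may have more. Where it says the series, first, only, none or still open, it means among the compounds named here.

Among the measured compounds shown here, in a physicochemical assay for lipophilicity, read by HPLC, measured as octanol-water partition (a lower number here means a more polar compound, a higher number a more lipophilic compound), three compounds have numbers so far. Compound 1 (`N#Cc1c(-c2ccco2)[n+]([O-])c2ccc(C3OCCO3)cc2[n+]1[O-]`) reads highest (2) and compound 2 (`N#Cc1c(-c2ccccc2)[n+]([O-])c2ccc(/C=N/NC(=O)c3ccncc3)cc2[n+]1[O-]`) lowest (1). Compound 3 (`Nc1cccc(C(=O)N/N=C/c2ccc3no[n+]([O-])c3c2)c1`) falls in the middle (1.4), above compound 2 and below compound 1, with both gaps beyond the scatter of repeated measurements.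

Compound 4 (`O=C(N/N=C/c1ccc2no[n+]([O-])c2c1)c1ccc(O)cc1`) differs from compound 3 in a single place (4-hydroxyphenyl in place of 3-aminophenyl on a carbonyl carbon): 4-hydroxyphenyl stands in place of 3-aminophenyl on a carbonyl carbon. Both groups are a six-membered aromatic ring of carbon only, and nitrogen gives way to oxygen in the counted atoms.

For the measured compounds named here, no measured pair shows this swap, so the starting point is simply compound 3 (1.4), and the size of the change remains a judgement. A small rise in this assay is expected (a number 0.20 log units higher from compound 3 to compound 4 (within the scatter)), close to the scatter. Compound 4 is estimated to read (1.6), with an expected range from 1.1 to 2.1 in this measurement.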

Compound 4, partition coefficient: 1.2
Compound 4: the middle estimate sits 0.40 log units above what was measured, and the stated range covers the measured number.
By their numbers in this assay, from the lowest: compounds 2, 4 and 3 (each within the scatter of the next, the first and the last beyond it); then compound 1.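

Among the compounds shown here, this is the first pair in the set that differs in only one place, so it gives the first direct reading at the carbonyl carbon whose other neighbour is the amide-type nitrogen. In this assay, putting 4-hydroxyphenyl in place of 3-aminophenyl gives a number 0.20 log units lower from compound 3 to compound 4 (within the scatter), so this swap, between two groups that match in heavy atoms, donors and acceptors as counted, cannot be told apart from repeat variation. Nothing available explains why the two compounds read as they do.

The swap alters both the ring's substituent and its place on the ring, and this single pair cannot separate those two changes. From the compounds shown here alone, how a plain phenyl, a pyridine ring or a longer alkyl chain on that carbonyl carbon would read remains open.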